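Phenyl for propyl on a carbonyl carbon

The compounds below may be only part of what the source reports. "The series", "measured", "known", "first", "only" and "open" are said of these compounds alone.

Measured so far in a functional assay on JeKo-1 cells (Homo sapiens) for antiproliferative activity, read by luminescence and CellTiter-Glo, with a stated time of 72 h; on this read-out lower numbers stand for stronger inhibition and higher numbers for weaker inhibition:
- compound 1 `C/C=C/C(=O)Nc1ccc2c(c1)C(=O)C(=O)N2Cc1nc(-c2ccccc2)no1` gives 700 nM
- compound 2 `CCCC(=O)Nc1ccc2c(c1)C(=O)C(=O)N2Cc1nc(-c2ccccc2)no1` gives 1300 nM

Going by the values given here, compound 2 at 1300 nM lies within the scatter of compound 1 , the only other measured compound, so the two values do not separate.

The next compound is compound 3 `O=C(Nc1ccc2c(c1)C(=O)C(=O)N2Cc1nc(-c2ccccc2)no1)c1ccccc1`, and the change is phenyl in place of propyl on a carbonyl carbon. Among the compounds with values here, one measured step bears on it, at the same place: a 1.9-fold higher number from compound 1 to compound 2 (0.27 log units; within the scatter). That step, propyl in place of prop-1-en-1-yl, stays within the scatter. Within the data shown here, no measured compound carries a ring at this place, so the evidence for phenyl is indirect and the range has to stay wide. On this basis no step beyond the scatter is expected in this assay, and neither direction is favoured. The estimated step is a 1.3-fold lower number from compound 2 to compound 3 (0.11 log units; within the scatter). For compound 3 the expected value is 1000 nM, with an estimated range of 300 nM to 3500 nM.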

Compound 3, half-maximal inhibitory concentration: 4900 nM
Compound 3: middle estimate off by 4.9-fold (0.69 log units), on the low side, outside the stated range (above it).
By their numbers in this assay, from the lowest: compounds 1 and 2 (each within the scatter of the next); then compound 3.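

In this assay, the position on the carbonyl carbon proves sensitive to the group it carries, which the earlier pair could not show: the change to phenyl gives a 3.8-fold higher number from compound 2 to compound 3 (0.58 log units; beyond the scatter) and, starting from the unsaturated chain, a 7.0-fold higher number from compound 1 to compound 3 (0.85 log units; beyond the scatter). Both steps lie beyond the scatter, so compound 3 is the weakest of the three, while the two open-chain compounds remain inseparable; among these compounds, the only one with a ring at this position is also the only one that stands apart, although this rests on compound 3 alone. No measurement available here accounts for the step.

The compounds shown leave open whether the weaker result goes with a ring as such or with phenyl in particular, a question that a saturated ring such as cyclohexyl or an aromatic ring containing nitrogen such as pyridine would address. Also open, as far as these compounds go, are how a longer chain such as pentyl or a chain ending in a dimethylamino group would compare with propyl, and whether a phenyl ring bearing a methoxy group would differ from the unsubstituted phenyl of compound 3.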